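A few compounds are considered here, and "the series" means these few. Any claim that something is new, unique, unknown or untested is made for them only; others in the source may bear on it.

Of the compounds shown here, two have so far been tested in a functional assay on A549 cells (Homo sapiens) for cytotoxicity, read by MTT assay, with a stated time of 48 h; on this read-out higher numbers stand for weaker inhibition and lower numbers for stronger inhibition. Compound 1 `Cc1nnc(SCC(=O)c2ccc(Cl)cc2)n1N1C(=O)c2ccccc2C1=O` reached only the upper limit of the assay, recorded as > 200000 nM. Compound 2 `CCc1nnc(SCC(=O)c2ccccc2)n1N1C(=O)c2ccccc2C1=O` also gave only a limit, > 200000 nM. Compound 2 thus stands at the limit where both values shown sit (the limit of > 200000 nM in this assay, at which 2 of the 2 values shown sit). Compound 3 `CCc1nnc(SCC(=O)c2ccc(Cl)cc2)n1N1C(=O)c2ccccc2C1=O` differs from compound 2 in one place: chloro in place of hydrogen on an aromatic carbon. For the measured compounds named here, no step between measured compounds is known. Compound 1 carries chloro and gives only the limit > 200000 nM. The step from compound 2 to compound 3 is expected to be a step that the limit leaves unreadable from compound 2 to compound 3, nothing beyond the scatter. Compound 3 is expected to give 300000 nM, between 150000 nM and 1000000 nM.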

Compound 3, half-maximal inhibitory concentration: > 200000 nM
Compound 3: no number, only a limit; the forecaster's own chance of this, stated with the estimate: 90%; the middle value does not contradict the limit.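

For the compounds shown here, compound 3 gives only a limit, so no step linking it to compound 1 or compound 2 can be read: the limit of > 200000 nM in this assay, at which 3 of the 3 values shown sit. From the compounds shown here alone, how strongly any of these three compounds acts in this assay, and whether chloro in place of hydrogen changes that, stays open.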